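A few compounds are considered here, and "the series" means these few. Any claim that something is new, unique, unknown or untested is made for them only; others in the source may bear on it.

Compound 1 `CC(C)OC(=O)N1CCC(n2ncc3cc(-c4ccc(S(C)(=O)=O)cc4)ncc32)CC1` is measured in a functional assay on HEK293 cells for agonist activity at Glucose-dependent insulinotropic receptor (Homo sapiens), read by cAMP accumulation, with a stated time of 30 min (on this read-out higher numbers stand for an effect only at larger amounts of compound and lower numbers for an effect already at smaller amounts), where compound 1 gives 42 nM. Compound 2 `CC(C)OC(=O)N1CCC(n2ncc3cc(-c4ccc(C(N)=O)cc4F)ncc32)CC1`, which differs from it in one place, gives 97 nM in this assay; this single step, a 2.3-fold higher number from compound 1 to compound 2 (0.36 log units; beyond the scatter), is the only one available, and it leaves compound 1 with the lowest of the two numbers.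

Compound 3 `CC(C)CCN1CCC(n2ncc3cc(-c4ccc(S(C)(=O)=O)cc4)ncc32)CC1` carries the change (isopentyl in place of isopropoxycarbonyl on an amine nitrogen in a ring). Among the measured compounds shown here, no measured step touches the amine nitrogen in the ring, so nothing known bears on this change, and the expectation is correspondingly uncertain. Compound 3 is estimated at 150 nM, with a range from 30 nM to 800 nM; this estimate means a 3.6-fold higher number from compound 1 to compound 3 (0.55 log units; beyond the scatter).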

Compound 3, half-maximal effective concentration: 220 nM
The estimate for compound 3 lay 1.5-fold (0.17 log units) below the measured number; measured number inside the range.
By their numbers in this assay, from the lowest: compound 1; then compound 2; then compound 3.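

The amine nitrogen in the ring, untouched by the earlier step, turns out to respond to substitution: in this assay, putting isopentyl in place of isopropoxycarbonyl gives a 5.2-fold higher number from compound 1 to compound 3 (0.72 log units; beyond the scatter). The isopropoxycarbonyl group is therefore not required for activity, since compound 3 still gives 220 nM, although a larger amount is needed. No measurement shown explains this shift. On these data alone, whether a shorter chain, a benzyl group or an acetyl group on this nitrogen would come closer to compound 1 remains open. This single step also cannot separate the loss of the carbonyl from the loss of the oxygen in the chain.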